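This account rests on a few compounds, and the source may have more. Where it says the series, first, only, none or still open, it means among the compounds named here.

Working notes on the series. Among the measured compounds shown here, in a functional assay on DU-145 cells (Homo sapiens) for inhibition, read by trypan blue exclusion, with a stated time of 96 h (on this read-out lower numbers stand for stronger inhibition of growth and higher numbers for weaker inhibition of growth), compound 1 (`CSc1ccc(/C=C(\C(=O)c2ccc(Br)cc2)S(=O)(=O)Cc2ccc(F)cc2)cc1`) stands highest of the two numbers so far at 50000 nM, beyond the scatter from compound 2 (`O=C(/C(=C\c1csc([N+](=O)[O-])c1)S(=O)(=O)c1ccc(Br)cc1)c1ccc(Br)cc1`), which gives 1000 nM but is not a single-place neighbour. Compound 3 (`Cc1ccc(C)c(/C=C(\C(=O)c2ccc(Br)cc2)S(=O)(=O)Cc2ccc(F)cc2)c1`) departs from compound 1 in one place (2,5-dimethylphenyl in place of 4-(methylsulfanyl)phenyl on a double-bonded chain carbon bound to a double-bonded chain carbon), with 2,5-dimethylphenyl in place of 4-(methylsulfanyl)phenyl. For the measured compounds named here, no measured step guides this change, so only a tentative expectation is possible in this assay, of a moderate move toward stronger inhibition of growth, estimated as a 3.3-fold lower number from compound 1 to compound 3 (0.52 log units; beyond the scatter) overall. Compound 3 is expected at 15000 nM with an estimated range from 3000 nM to 60000 nM on this read-out.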

Compound 3, concentration for 50% growth inhibition: 1000 nM
For compound 3 the middle estimate is 15-fold (1.18 log units) above the measured one, outside the stated range (below it).
By their numbers in this assay, from the lowest: compounds 2 and 3 (each within the scatter of the next); then compound 1.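

Among the compounds shown here, at this place, on a double-bonded chain carbon bound to a double-bonded chain carbon, the first single-place step shows that the aryl group alone can move the number strongly in this assay: 2,5-dimethylphenyl in place of 4-(methylsulfanyl)phenyl gives a 50-fold lower number from compound 1 to compound 3 (1.70 log units; beyond the scatter). The swap keeps the heavy-atom count and exchanges sulfur and its hydrogen-bond acceptor for carbon. No available evidence accounts for this step. Still open, going by these compounds, is whether losing the methylsulfanyl group or gaining the two methyl groups drives the step, and how an amine or a carboxylic acid on this phenyl ring would read.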